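Iodo for ethoxy on the shared core of the series

The compounds below may be only part of what the source reports. "The series", "measured", "known", "first", "only" and "open" are said of these compounds alone.

For the measured compounds named here, in a functional assay on CHO cells for antagonist activity at Orexin receptor type 2 (Homo sapiens), read by FLIPR and calcium flux (on this read-out lower numbers stand for stronger inhibition and higher numbers for weaker inhibition), compound 1 `C=Cc1nc(CC)n2c1C(CCc1ccc(C(F)(F)F)cc1)N([C@@H](C(=O)NC)c1ccccc1)CC2` gives 23 nM, while compound 2 `CCOc1nc(CC)n2c1C(CCc1ccc(C(F)(F)F)cc1)N([C@@H](C(=O)NC)c1ccccc1)CC2` gives 2750 nM, the highest of the two numbers; the only step so far, a 120-fold higher number from compound 1 to compound 2 (2.08 log units; beyond the scatter), bears on the present change. Compound 3 `CCc1nc(I)c2n1CCN([C@@H](C(=O)NC)c1ccccc1)C2CCc1ccc(C(F)(F)F)cc1` differs from compound 2 by iodo in place of ethoxy on an aromatic carbon. With ethoxy removed and a single-atom substituent entering, compound 3 is expected to move back toward compound 1 rather than stay with compound 2, an estimated step of a 28-fold lower number from compound 2 to compound 3 (1.44 log units; beyond the scatter) in this assay. Compound 3 is therefore estimated at 100 nM, with a range from 20 nM to 800 nM.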

Compound 3, half-maximal inhibitory concentration: 23 nM
Compound 3: the middle estimate sits 4.3-fold (0.64 log units) above what was measured, within the range that was stated.
By their numbers in this assay, from the lowest: compounds 1 and 3 (each within the scatter of the next); then compound 2.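

Within this assay the change from ethoxy to iodo on this aromatic carbon brings a 120-fold lower number from compound 2 to compound 3 (2.08 log units; beyond the scatter) and, set against vinyl, no change at the digits printed from compound 1 to compound 3 (within the scatter). The position therefore tolerates both iodo and vinyl equally in this series, and among the three compounds only compound 2, with ethoxy, goes against that. No data at hand account for what separates ethoxy from the other two groups.

Going by these compounds, whether the higher number of compound 2 follows the oxygen or the chain of ethoxy stays open. Methoxy and propyl on the same aromatic carbon would separate the two.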